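This account rests on a few compounds, and the source may have more. Where it says the series, first, only, none or still open, it means among the compounds named here.

Compound 1 `COc1ccc(C(N)=O)cc1S(=O)(=O)Nc1cccnc1`: 1490 nM
Compound 2 `COc1ccc(C(F)(F)F)cc1S(=O)(=O)Nc1cnc2ccccc2c1`: 26 nM

Of the compounds shown here, two have been measured in an assay on isolated protein for inhibition of alkaline phosphatase, tissue-nonspecific isozyme (Homo sapiens); on this read-out higher numbers stand for weaker inhibition and lower numbers for stronger inhibition. Compound 1 gives 1490 nM, the higher of the two numbers and so the weaker inhibitor of the pair. Compound 2 gives 26 nM, and the gap between the two lies well beyond the usual scatter of this assay. Compound 2 differs from compound 1 in more than one place, so no single structural change can be tied to that gap.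

Compound 3 `COc1ccc(C#N)cc1S(=O)(=O)Nc1cccnc1` has not yet been measured. It differs from compound 1 in one place only: cyano in place of carbamoyl on an aromatic carbon. Among the compounds with values here, no measured pair shows this particular change, so nothing here tells how large its effect is. Given that, a cautious expectation is a modest step toward a lower number, meaning somewhat stronger inhibition, estimated as a 1.9-fold lower number from compound 1 to compound 3 (0.27 log units; within the scatter) from compound 1 to compound 3, though a result within the scatter would not surprise. For compound 3 the expected value is 800 nM, with a range from 250 nM to 2500 nM.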

Compound 3, half-maximal inhibitory concentration: 322 nM
The estimate for compound 3 lay 2.5-fold (0.40 log units) above the measured number, within the range that was stated.
By their numbers in this assay, from the lowest: compound 2; then compound 3; then compound 1.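

In this assay, putting cyano in place of carbamoyl on the aromatic carbon para to a methoxy group and meta to a large group gives a 4.6-fold lower number from compound 1 to compound 3 (0.67 log units; beyond the scatter). Within the data shown here, this is the first change here that can be read on its own, and it shows that inhibition responds to what sits on this carbon, since the rest of the structure stays the same. Carbamoyl has 1 hydrogen-bond donor and cyano has 0, so a donor on this carbon is not needed for the stronger inhibition seen here, although no measurement at hand explains the size of the step.

This single swap changes the donor count and the heavy-atom count together, so the compounds shown cannot say which of the two matters, or whether either does. Trifluoromethyl appears on this carbon only in compound 2, which also differs elsewhere, so its effect cannot be read, and it remains open how a carboxylic acid, a methyl ester or a single chlorine atom on this carbon would compare with cyano.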